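The compounds below may be only part of what the source reports. "The series", "measured", "known", "first", "only" and "open" are said of these compounds alone.

- compound 1 `O=C(N/N=C/c1cccc(Cl)c1Cl)Nc1cc2c(Nc3ccc(F)c(Cl)c3)ncnc2cc1O[C@H]1CCOC1`: 27400 nM
- compound 2 `COc1ccc(/C=N/NC(=O)Nc2cc3c(Nc4ccc(F)c(Cl)c4)ncnc3cc2O[C@H]2CCOC2)cc1`: 34100 nM
- compound 3 `O=C(N/N=C/c1ccc(O)c(Br)c1)Nc1cc2c(Nc3ccc(F)c(Cl)c3)ncnc2cc1O[C@H]1CCOC1`: 5230 nM

These three compounds were tested in a functional assay on PC-3 cells (Homo sapiens) for cytotoxicity, read by MTT assay, with a stated time of 72 h; a higher number here means a weaker inhibitor, a lower number a stronger inhibitor. Compound 3 has the lowest number of the three, and both of its gaps lie beyond the scatter: a 5.2-fold lower number from compound 1 to compound 3 (0.72 log units; beyond the scatter) and a 6.5-fold lower number from compound 2 to compound 3 (0.81 log units; beyond the scatter). Compound 1 and compound 2 cannot be told apart, with a 1.2-fold higher number from compound 1 to compound 2 (0.10 log units; within the scatter).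

Compound 4 `O=C(N/N=C/c1ccc(O)cc1O)Nc1cc2c(Nc3ccc(F)c(Cl)c3)ncnc2cc1O[C@H]1CCOC1` carries a 2,4-dihydroxyphenyl in place of the 3-bromo-4-hydroxyphenyl on a carbon with a double bond to nitrogen: 2,4-dihydroxyphenyl in place of 3-bromo-4-hydroxyphenyl on a carbon with a double bond to nitrogen. For the measured compounds named here, no measured step contains the 2,4-dihydroxyphenyl group, so the data give no direct guide to this change. The nearest evidence is that the only two replacements of the 3-bromo-4-hydroxyphenyl group seen so far, read in reverse from a 5.2-fold lower number from compound 1 to compound 3 (0.72 log units; beyond the scatter) and a 6.5-fold lower number from compound 2 to compound 3 (0.81 log units; beyond the scatter), both lead to higher numbers. A modest move in that direction is therefore expected in this assay, probably no larger than those two steps. The expected step is a 2.7-fold higher number from compound 3 to compound 4 (0.43 log units; beyond the scatter). For compound 4 the estimate is 14000 nM, with an expected range from 4000 nM to 40000 nM.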

Compound 4, half-maximal inhibitory concentration: 7540 nM
Beside the measured number, compound 4's estimate is 1.9-fold (0.27 log units) above it; measured number inside the range.
By their numbers in this assay, from the lowest: compounds 3 and 4 (each within the scatter of the next); then compounds 1 and 2 (each within the scatter of the next).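

In this assay, the 2,4-dihydroxyphenyl group, which has no bromine, cannot be told apart from the 3-bromo-4-hydroxyphenyl group (a 1.4-fold higher number from compound 3 to compound 4 (0.16 log units; within the scatter)), so at this place on a carbon with a double bond to nitrogen, the bromine is not required for a number in this range. The new group also stands clear of the other two groups (a 4.5-fold lower number from compound 2 to compound 4 (0.66 log units; beyond the scatter); a 3.6-fold lower number from compound 1 to compound 4 (0.56 log units; beyond the scatter)), and among these four compounds, the two with the lower numbers are the two with a hydroxy group on the ring, with no compound going against this. Nothing available explains this link.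

As far as these compounds go, it remains open whether a plain 4-hydroxyphenyl group, or a 4-aminophenyl group or a ring bearing a carboxylic acid, would fall with compound 3 and compound 4. Also open, from the compounds shown here alone, is whether any group at this place would take the number well under that of compound 3 (5230 nM).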